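The source may hold more compounds than are shown below. What is called first, only, known or untested is meant among the compounds shown, and "the series" means these compounds.

In a functional assay on HepG2 cells (Homo sapiens) for cytotoxicity, read by sulforhodamine B assay, with a stated time of 48 h (a higher number here means a weaker inhibitor, a lower number a stronger inhibitor), compound 1 `COc1ccc(-c2c(C#N)c(N)n(/N=C(/C)c3ccc(NS(=O)(=O)c4ccc(C)cc4)cc3)c(=O)c2C#N)cc1` gives 31800 nM, and compound 2 `Cc1ccc(S(=O)(=O)Nc2ccc(-c3cc(-c4ccc([N+](=O)[O-])cc4)n(C(=S)NN)n3)cc2)cc1` gives 45300 nM; both sit in the weak range of this assay. Compound 3 `Cc1ccc(S(=O)(=O)Nc2ccc(C(=O)/C=C/c3ccccc3)cc2)cc1` shares the sulfonamide-bearing part of these structures but carries a cinnamoyl-type side chain, and in this assay compound 3 is reported as "not active" (no number reported), so no single number marks where it stands, only that it is weaker than the two compounds that did give a value. Compound 4 `Cc1ccc(S(=O)(=O)Nc2ccc(C(=O)/C=C/c3ccc(Br)cc3)cc2)cc1` is the next compound and has not yet been measured in this assay. It differs from compound 3 by the change (bromo in place of hydrogen on an aromatic carbon). Among the measured compounds shown here, with compound 3 giving no number and no step between measured compounds of this kind available, there is nothing in the present data that points to a shift one way or the other beyond the usual scatter of this assay. The expectation is therefore that compound 4 stays in the weak range, in line with compound 1 at 31800 nM and compound 2 at 45300 nM, and it is estimated at 45000 nM, with a range from 15000 nM to 150000 nM, while a report of inactivity with no number remains quite possible.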

Compound 4, half-maximal inhibitory concentration: 30300 nM
Compound 4: the middle estimate sits 1.5-fold (0.17 log units) above what was measured, within the range that was stated.
By their numbers in this assay, from the lowest: compounds 4, 1 and 2 (each within the scatter of the next).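

In this assay compound 4 gives 30300 nM but compound 3 has no number, so no step can be read between these two compounds. On these data alone, how far the bromo group shifts the reading stays open, and no measured evidence bears on this result.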